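The source may hold more compounds than are shown below. What is called first, only, known or untested is meant among the compounds shown, and "the series" means these compounds.

Measured in a functional assay on Ca-Ski cells (Homo sapiens) for antiproliferative activity, with a stated time of 48 h; on this read-out higher numbers stand for weaker inhibition and lower numbers for stronger inhibition:
- compound 1 `COc1cc(O)c(C(=O)/C=C/c2ccccc2)cc1I` gives > 50000 nM
- compound 2 `CCCOc1ccc(C(=O)/C=C/c2ccccc2)c(O)c1` gives > 50000 nM

Neither entry is a true number. Each is a limit of the assay, so the actual half-maximal concentration was not determined for either compound. For the measured compounds named here, compound 1 stands at the limit of > 50000 nM in this assay, at which 2 of the 2 values shown sit, and this shows only that no number was obtained for it. Compound 2 shares that limit, and the two compounds therefore cannot be ranked against each other.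

The next compound is compound 3 `COc1cc(O)c(C(=O)/C=C/c2ccccc2)cc1Br`, which keeps the core of compound 1 and changes one substituent: bromo in place of iodo on an aromatic carbon. In words, this is bromo in place of iodo on an aromatic carbon. Going by the values given here, no measured pair of compounds shows what a single change of this kind does. In this assay, a step no larger than the usual scatter is therefore expected, in neither direction. That expectation rests on compound 1 and its limit of > 50000 nM. The most likely report is another limit. The estimated step is a number no higher from compound 1 to compound 3 (the limit leaves the size open). For compound 3 the estimated value is 50000 nM, with an expected range from 20000 nM to 100000 nM.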

Compound 3, half-maximal inhibitory concentration: > 50000 nM
Compound 3 ended at the assay's limit; the forecaster's own chance of this, stated with the estimate: 75%; the middle value sits exactly at the limit.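

For the compounds shown here, compound 3 ends on a limit and not a number, as compound 1 does, so no step between compound 1 and compound 3 can be read in this assay: the limit of > 50000 nM in this assay, at which 3 of the 3 values shown sit. Going by these compounds, what bromo in place of iodo on an aromatic carbon does to the half-maximal concentration stays open, as do the true values of all three compounds.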